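Cyclohexylamino on a carbonyl carbon after two limits

A few compounds are considered here, and "the series" means these few. Any claim that something is new, unique, unknown or untested is made for them only; others in the source may bear on it.

Values so far in a functional assay on K562 cells (Homo sapiens) for antiproliferative activity, read by MTT assay; a higher number here means a weaker inhibitor, a lower number a stronger inhibitor:
compound 1 `CCOC(=O)N1CCCc2cc(S(=O)(=O)N3CC(c4ccccc4)NC3=O)ccc21` gives > 20000 nM as a limit
compound 2 `O=C1NC(c2ccccc2)CN1S(=O)(=O)c1ccc2c(c1)CCCN2C(=O)C(F)(F)F` gives > 20000 nM as a limit

Compound 2 stands at > 20000 nM and that is a limit, not a number. The record so far is the limit of > 20000 nM in this assay, at which 2 of the 2 values shown sit, and nothing more. Compound 3 `O=C(NC1CCCCC1)N1CCCc2cc(S(=O)(=O)N3CC(c4ccccc4)NC3=O)ccc21` carries cyclohexylamino in place of trifluoromethyl on a carbonyl carbon. Within the data shown here, the one measured step that bears on this is a step that the two limits leave unreadable from compound 1 to compound 2 and it offers no size to carry over. The expected change is an at least 2.2-fold lower number from compound 2 to compound 3 (0.34 log units; beyond the scatter) in the direction of a stronger inhibitor, with nothing measured to size it. Compound 3 is estimated at 9000 nM with an expected range of 1500 nM to 20000 nM in this measurement.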

Compound 3, half-maximal inhibitory concentration: 813 nM
Estimate against measurement, compound 3: 11-fold (1.04 log units) above; the measured number lies below the stated range.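

Among these compounds, compound 3 is the first compound here to give a number rather than a limit in this assay, and the other two remain at that limit: the limit of > 20000 nM in this assay, at which 2 of the 3 values shown sit. Cyclohexylamino in place of trifluoromethyl gives an at least 24-fold lower number from compound 2 to compound 3 (1.39 log units; beyond the scatter), and in place of ethoxy it gives an at least 24-fold lower number from compound 1 to compound 3 (1.39 log units; beyond the scatter). The group on this carbonyl carbon can therefore move the result by a large step, whose full size the limits hide.

The compounds shown do not separate the ring of cyclohexylamino from its amide hydrogen. A methylamino group, which has no ring, or a piperidine attached through its nitrogen, which has no such hydrogen, would bear on that.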